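Swapping the side chain on a fused-ring agonist core

The compounds below may be only part of what the source reports. "The series", "measured", "known", "first", "only" and "open" are said of these compounds alone.

Compound 1 `Cc1cc(C)n(CCOC2CC(=O)Nc3c2c(C)nn3-c2ncnc3nc[nH]c23)n1` is one of three compounds tested in a functional assay on HEK293 cells for agonist activity at G-protein coupled receptor 39 (Homo sapiens), read by scintillation proximity assay and inositol phosphate accumulation, with a stated time of 75 min (on this read-out lower numbers stand for an effect already at smaller amounts and higher numbers for an effect only at larger amounts of compound), and compound 1 gives 2000 nM, the second highest of the three numbers. Compound 3 `Cc1cc(C)nc(-n2nc(C)c3c2NC(=O)CC3c2ccc(COc3cccc(Cl)c3)cc2)n1` gives 3000 nM, a value within the scatter of compound 1. Compound 2 `CCCCCCCCOC1CC(=O)Nc2c1c(C)nn2-c1ncnc2nc[nH]c12` gives 388 nM. Among the measured compounds shown here, the only measured step touching the same part of the shared core is a 5.2-fold lower number from compound 1 to compound 2 (0.71 log units; beyond the scatter). Compound 4 `Cc1nn(-c2ncnc3nc[nH]c23)c2c1C(NC(=O)Cc1cccs1)CC(=O)N2` differs from compound 1 by a group of 9 heavy atoms (6 carbon, 1 nitrogen, 1 oxygen, 1 sulfur; one five-membered aromatic ring with 1 hetero atom) in place of a group of 10 heavy atoms (7 carbon, 2 nitrogen, 1 oxygen; one five-membered aromatic ring with 2 hetero atoms), on a saturated ring carbon, on a saturated ring carbon three ring bonds from the ring nitrogen. For the measured compounds named here, no measured step covers this exact change; the hexyl swap only shows that altering this position can move the number beyond the scatter. The estimate for compound 4 is therefore cautious, expected as a 1.3-fold lower number from compound 1 to compound 4 (0.12 log units; within the scatter), giving 1500 nM with a range from 300 nM to 6000 nM.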

Compound 4, half-maximal effective concentration: 244 nM
The estimate for compound 4 lay 6.1-fold (0.79 log units) above the measured number; the measured number lies below the stated range.
By their numbers in this assay, from the lowest: compounds 4 and 2 (each within the scatter of the next); then compounds 1 and 3 (each within the scatter of the next).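

On this saturated ring carbon, (((thiophen-2-yl)methyl)carbonyl)amino gives an 8.2-fold lower number from compound 1 to compound 4 (0.91 log units; beyond the scatter) in this assay, so a group attached through nitrogen can also lower the number, where compounds 1 and 2 both carry oxygen at this spot. Set against octyloxy, the same group gives a 1.6-fold lower number from compound 2 to compound 4 (0.20 log units; within the scatter), so these two quite different groups cannot be told apart here. Nothing measured here explains this result. The compounds shown leave open whether the thiophene ring or the amide hydrogen matters more, and how a phenyl ring in place of thiophene or a free amine on this carbon would read.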